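A few compounds are considered here, and "the series" means these few. Any claim that something is new, unique, unknown or untested is made for them only; others in the source may bear on it.

In a physicochemical assay for solubility, read by HPLC, in phosphate buffer, measured as kinetic solubility, with a stated time of 1 h, at pH 7.4, tested at 250 uM (a lower number here means a less soluble compound, a higher number a more soluble compound), compound 1 `O=C(NCCCCc1ccccc1)n1cc(-c2ccccc2)oc1=O` gives < 1000 nM as a limit and not a number. Compound 2 `O=C(NCCCCc1ccccc1)n1cc(-c2cccnc2)oc1=O` gives < 1000 nM which is also a limit. Compound 3 `O=C(NCCCCc1ccccc1)n1cc(-c2cnccn2)oc1=O` gives < 1000 nM which is again a limit. Together these results amount to the limit of < 1000 nM in this assay, at which 3 of the 3 values shown sit, and nothing firmer. Compound 4 `CN1CCC(c2cccc(-c3cn(C(=O)NCCCCc4ccccc4)c(=O)o3)c2)CC1` carries 1-methylpiperidin-4-yl in place of hydrogen on an aromatic carbon of a six-membered aromatic ring of carbon only, meta to a large group, and 1-methylpiperidin-4-yl in place of hydrogen on an aromatic carbon counts that change. The nearest measured changes are a step that the two limits leave unreadable from compound 1 to compound 2 and a step that the two limits leave unreadable from compound 1 to compound 3 and neither gives a size to carry over. An upward move is expected as an at least 20-fold higher number from compound 1 to compound 4 (1.30 log units; beyond the scatter) but its size is only loosely estimated. For compound 4 the expected value is 20000 nM within an estimated range of 1000 nM to 150000 nM in this measurement.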

Compound 4, solubility: 70000 nM
The estimate for compound 4 lay 3.5-fold (0.54 log units) below the measured number, and the stated range covers the measured number.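

In this assay, 1-methylpiperidin-4-yl in place of hydrogen on an aromatic carbon, meta to a large group, comes with an at least 70-fold higher number from compound 1 to compound 4 (1.84 log units; beyond the scatter). This is the first step in the series with a readable size, since the steps among the earlier compounds, which swap one aromatic ring for another, cannot be read: the limit of < 1000 nM in this assay, at which 3 of the 4 values shown sit.

The compounds shown leave open which part of the new group goes with this step. A cyclohexyl or a morpholine group at the same place could help separate the ring from its nitrogen.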